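Exchanging the ether substituent on a weakly active pair

A few compounds are considered here, and "the series" means these few. Any claim that something is new, unique, unknown or untested is made for them only; others in the source may bear on it.

Compound 1 `C=CCOc1cc(/C=C\c2cc(OC)c(OC)c(OC)c2)ccc1OC` gives 12000 nM here
Compound 2 `COc1ccc(/C=C\c2cc(OC)c(OC)c(OC)c2)cc1OCc1ccc(Br)cc1` gives 29000 nM here

Both numbers come from a functional assay on MCF7 cells (Homo sapiens) for inhibition, read by MTT assay, with a stated time of 3 days (a lower number here means a stronger inhibitor, a higher number a weaker inhibitor), and compound 2 at 29000 nM is the higher of the two, which makes it the weaker inhibitor of this pair. Going by the values given here, only one measured step exists, a 2.4-fold higher number from compound 1 to compound 2 (0.38 log units; beyond the scatter) and it came with 4-bromophenyl in place of vinyl on a saturated chain carbon bound to an oxygen on an aromatic ring.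

Compound 3 `COc1ccccc1/C=C/CCCOc1cc(/C=C\c2cc(OC)c(OC)c(OC)c2)ccc1OC` has not yet been measured. The change from compound 2 is 4-(2-methoxyphenyl)but-3-en-1-yl in place of 4-bromophenyl on a saturated chain carbon bound to an oxygen on an aromatic ring and it sits at that same saturated chain carbon bound to an oxygen on an aromatic ring, with 4-(2-methoxyphenyl)but-3-en-1-yl as the new group. Among the compounds with values here, no measured compound carries this group, so the direction is uncertain, and the single modest step from compound 1 is the only guide to size. In this assay the expected outcome is a 1.3-fold lower number from compound 2 to compound 3 (0.12 log units; within the scatter) as an estimate, a small shift at most. For compound 3 the estimated value is 22000 nM with an expected range from 8000 nM to 60000 nM as its bounds.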

Compound 3, half-maximal inhibitory concentration: 21000 nM
Compound 3: middle estimate off by 1.0-fold (0.02 log units), on the high side; measured number inside the range.
By their numbers in this assay, from the lowest: compounds 1, 3 and 2 (each within the scatter of the next, the first and the last beyond it).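

In this assay, the step to the new group, a 1.4-fold lower number from compound 2 to compound 3 (0.14 log units; within the scatter), stays within the scatter, even though 4-(2-methoxyphenyl)but-3-en-1-yl, with 12 heavy atoms, replaces 4-bromophenyl, with 7, and brings a double bond outside aromatic rings and a hydrogen-bond acceptor. The comparison with the small group, a 1.8-fold higher number from compound 1 to compound 3 (0.24 log units; within the scatter), is also within the scatter, so compound 3 cannot be separated from either earlier compound, and the gap between compound 1 and compound 2 remains the only difference beyond the scatter in this set. This position on a saturated chain carbon bound to an oxygen on an aromatic ring therefore carries very different groups with little separation in the read-out, and no evidence is available to explain this.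

From the compounds shown here alone, the new group cannot be divided here, so the separate contributions of its 2-methoxyphenyl ring and its chain remain unknown. Going by these compounds, it also remains open whether an amine or a carboxylic acid at this place would give a number clearly apart from these three.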